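Amide nitrogen substituent swap in a thienylmethyl acetamide series

The compounds below may be only part of what the source reports. "The series", "measured", "known", "first", "only" and "open" are said of these compounds alone.

Of the compounds shown here, three have numbers so far. Compound 1 `CCN(Cc1cccs1)C(=O)COc1ccc(F)cc1` gives 422 nM in an assay on HEK293 cells for agonist activity at transient receptor potential cation channel subfamily M member 8 (Homo sapiens), read by fluorescence and calcium flux, with a stated time of 15 min; a higher number here means that more compound is needed for the effect, a lower number that less compound is needed. Compound 3 `CCN(Cc1cccs1)C(=O)COc1ccccc1C` gives 192 nM in this assay. Compound 2 `C=CCN(Cc1cccs1)C(=O)COc1ccc(C)cc1` gives 20 nM in this assay, the lowest of the three numbers; its gaps to compound 3 and to compound 1 both lie beyond the scatter, so compound 2 needs the least material for the effect among the measured set.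

Compound 4 `Cc1ccc(OCC(=O)N(Cc2cccs2)c2cn[nH]c2)cc1` has not yet been measured in this assay. It shares the methyl-bearing aryloxy side with compound 2 and differs only at the amide-type nitrogen: 1H-pyrazol-4-yl in place of allyl on an amide-type nitrogen. Among the compounds with values here, none of the measured pairs differ in a single place, so no measured step sets the size of this change; the measured compounds differ from each other at two places at once. With a ring carrying a hydrogen-bond donor and acceptor entering where a short open chain leaves, a rise in the number beyond the scatter, of moderate size, is expected in this assay.

Compound 4 is estimated at 150 nM in this assay, with a range from 30 nM to 800 nM. This estimate corresponds to an expected step of a 7.5-fold higher number from compound 2 to compound 4 (0.88 log units; beyond the scatter).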

Compound 4, half-maximal effective concentration: 1.4 nM
Compound 4: middle estimate off by 110-fold (2.03 log units), on the high side, and the stated range ends above it.
By their numbers in this assay, from the lowest: compound 4; then compound 2; then compound 3; then compound 1.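

The amide-type nitrogen accepts a ring as well as a short open chain: 1H-pyrazol-4-yl in place of allyl gives a 14-fold lower number from compound 2 to compound 4 (1.15 log units; beyond the scatter) in this assay, and this is the only single-place step shown in the series, so it gives the first measured size for a change at this position. The number falls beyond the scatter as the group on this nitrogen goes from allyl, with no hydrogen-bond donor or acceptor, to a five-membered aromatic ring with one of each, which shows that an open chain is not required here for a low number. No supporting measurement ties the step to any single feature of the entering ring, and what produces it stays unassigned.

The compounds shown leave open which feature of the ring goes with the step; a phenyl ring, or a pyrazole bearing a methyl on its ring nitrogen, at the same place would begin to separate these features. They also leave open whether the step carries over to the other aryloxy sides, those of compound 1 and compound 3, which bear ethyl on this nitrogen.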